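The source may hold more compounds than are shown below. What is called first, only, known or untested is meant among the compounds shown, and "the series" means these compounds.

Measured so far in an assay on mitochondria from L6 cells (Rattus norvegicus) for activation, with a stated time of 90 min; on this read-out lower numbers stand for an effect already at smaller amounts and higher numbers for an effect only at larger amounts of compound:
compound 1, `Fc1cccc(Nc2nc3nonc3nc2Nc2ccccc2F)c1`, gives 190 nM;
compound 2, `CCCCOc1cccc(Nc2nc3nonc3nc2O)c1`, gives 2300 nM;
compound 3, `Oc1nc2nonc2nc1Nc1ccc(OCCCC(F)(F)F)c(F)c1`, gives 4200 nM.

Compound 3 stands at the highest of the three numbers in this assay. Its nearest neighbour is compound 2, and the gap between the two lies within the usual scatter of repeated measurements, so no order between compound 2 and compound 3 can be read from these values. Compound 1 lies far lower, and that gap is beyond the scatter.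

Compound 4, `Oc1nc2nonc2nc1Nc1cccc(F)c1`, has not yet been measured in this assay. It differs from compound 3 in one place: hydrogen in place of 4,4,4-trifluorobutoxy on an aromatic carbon. Among the measured compounds shown here, no pair among the measured compounds differs in a single place, so no measured step shows what this change does. For the measured compounds named here, compounds 2 and 3, which share the hydroxyl-bearing core of compound 4, both lie well above compound 1, and that is the only guide.

With a small chain-free aniline left, compound 4 is expected to give about 5000 nM in this assay, in a range from 1500 nM to 15000 nM. The step of a 1.2-fold higher number from compound 3 to compound 4 (0.08 log units; within the scatter) is expected to be modest, toward a somewhat higher number, and may well fall within the scatter.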

Compound 4, half-maximal effective concentration: 31200 nM
Beside the measured number, compound 4's estimate is 6.2-fold (0.80 log units) below it; the whole stated range lies below it.
By their numbers in this assay, from the lowest: compound 1; then compounds 2 and 3 (each within the scatter of the next); then compound 4.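

In this assay the step from butoxy-type chain to bare ring is now measured: hydrogen in place of 4,4,4-trifluorobutoxy on an aromatic carbon gives a 7.4-fold higher number from compound 3 to compound 4 (0.87 log units; beyond the scatter) and so shows that, on the hydroxyl-bearing core, the chain at this place counts for a clear part of the effect in this read-out. The comparison with the other chain-bearing compound agrees, since fluoro in place of butoxy on an aromatic carbon gives a 14-fold higher number from compound 2 to compound 4 (1.13 log units; beyond the scatter) even though that change involves a different ring place and not only the loss of a chain. With no chain left, the second aniline position matters still more, as hydroxy in place of (2-fluorophenyl)amino on an aromatic carbon gives a 160-fold higher number from compound 1 to compound 4 (2.22 log units; beyond the scatter) and is the widest step in this set.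

Nothing shown here says why these changes move the number as they do. Going by these compounds, what an amine, a methoxy group or a longer chain would give at this place stays open, as does whether the 4,4,4-trifluorobutoxy chain would have the same effect on the core of compound 1.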